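A few compounds are considered here, and "the series" means these few. Any claim that something is new, unique, unknown or untested is made for them only; others in the source may bear on it.

Measured so far in a functional assay on MDA-MB-231 cells (Homo sapiens) for antiproliferative activity, with a stated time of 48 h; a lower number here means a stronger inhibitor, a higher number a weaker inhibitor:
- compound 1 `CC(=O)c1ccc(-c2ccc(N3CCCC3)nn2)cc1`: > 25000 nM
- compound 2 `CCN(CC)c1ccc(-c2ccc(C(C)=O)cc2)nn1`: 5000 nM

Compound 1 gives > 25000 nM, which is a limit of the assay and not a number. Going by the values given here, compound 2, at 5000 nM, therefore holds the only true number so far.

Compound 3 `CCN(CC)c1ccc(-c2ccc(C(=O)O)cc2)nn1` differs from compound 2 in one place: hydroxy in place of methyl on a carbonyl carbon. This is hydroxy in place of methyl on a carbonyl carbon, or acetyl to carboxy when the cut is made one bond further out.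

Among the compounds with values here, only one measured step exists, an at least 5.0-fold lower number from compound 1 to compound 2 (0.69 log units; beyond the scatter), and it comes from diethylamino in place of pyrrolidin-1-yl at a different place. It sets no size for the acetyl to carboxy change, but it does show that a single change on this core can move the number beyond the scatter. With no direct measure of this change, a modest shift toward weaker inhibition is expected, with wide uncertainty. The estimated change is a 2.4-fold higher number from compound 2 to compound 3 (0.38 log units; beyond the scatter). For compound 3 the estimated value is 12000 nM, with an expected range from 3000 nM to 40000 nM.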

Compound 3, half-maximal inhibitory concentration: > 25000 nM
Compound 3: no number, only a limit; the forecaster's own chance of this, stated with the estimate: 35%; at least 2.0-fold (0.31 log units) between middle value and limit.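

Going by these compounds alone, the earlier step changed only the amine group, whereas compound 3 brings the first change at a second place: a carbonyl carbon whose other neighbour is an aromatic carbon. In this assay, replacing methyl with hydroxy there, which turns acetyl into carboxy, gives an at least 5.0-fold higher number from compound 2 to compound 3 (0.69 log units; beyond the scatter), so the diethylamino group alone is not enough to keep a measurable value and this second place matters as well. Compound 3 gives > 25000 nM, which is a limit of the assay and not a number, so the step shows a minimum size and its full size stays hidden: the limit of > 25000 nM in this assay, at which 2 of the 3 values shown sit.

The compounds shown leave open whether any other group on this carbonyl carbon would keep a measurable value or improve on compound 2, for example an amine, which would make an amide, a methoxy group, which would make a methyl ester, or a longer chain such as ethyl. Within the data shown here, with compound 2 as the only compound holding a true number, they also leave open how the diethylamino group and the group on the carbonyl carbon act together when both are changed.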